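The compounds below may be only part of what the source reports. "The series", "measured", "known", "first", "only" and "open" are said of these compounds alone.

Compound 1 `Cc1cccc(Cl)c1NC(=O)CN1CCN(c2nnc(Cc3ccncc3)c3ccccc23)CC1` is the weaker of the two compounds measured in a functional assay on HT-29 cells (Homo sapiens) for cytotoxicity, read by MTT assay, with a stated time of 72 h; a lower number here means a stronger inhibitor, a higher number a weaker inhibitor: compound 1 gives 22600 nM, while compound 2 `O=C(CN1CCN(c2nnc(Cc3ccccc3)c3ccccc23)CC1)Nc1ccc(F)c(C(F)(F)F)c1` gives 4590 nM, a gap beyond the usual scatter. Compound 3 `O=C(CN1CCN(c2nnc(Cc3ccncc3)c3ccccc23)CC1)Nc1c(F)cccc1F` has not been measured. It differs from compound 1 in one place: 2,6-difluorophenyl in place of 2-chloro-6-methylphenyl on an amide-type nitrogen. Among the compounds with values here, no measured pair shows what this swap does, and compound 2 changes more than one part at once, so it offers no clean guide. The step is expected to stay within the scatter, a 1.1-fold lower number from compound 1 to compound 3 (0.05 log units; within the scatter). Compound 3 is therefore estimated at 20000 nM, with a range of 6000 nM to 60000 nM.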

Compound 3, half-maximal inhibitory concentration: 28700 nM
Compound 3: the middle estimate sits 1.4-fold (0.16 log units) below what was measured; the measured number falls inside the stated range.
By their numbers in this assay, from the lowest: compound 2; then compounds 1 and 3 (each within the scatter of the next).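

In this assay, putting 2,6-difluorophenyl in place of 2-chloro-6-methylphenyl on the amide-type nitrogen gives a 1.3-fold higher number from compound 1 to compound 3 (0.10 log units; within the scatter), so compound 1 and compound 3 cannot be told apart. Within the data shown here, this is the first clean reading at this position, and it shows that these two substituted phenyl groups are interchangeable in this test. Nothing available bears on why the swap shows so little.

As far as these compounds go, it remains open whether a different group here, such as an unsubstituted phenyl or a cyclohexyl ring, would separate from these values. Compound 2 differs in more than one place, so its number cannot be tied to any single part.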